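The source may report more compounds than this note shows. Statements on the series, on what has been measured and on what is new or still open speak of the compounds shown alone.

Compound 1 `CCCCN(CC)c1nc(C)nc2c1nnn2-c1c(C)cc(C)nc1C` gives 65 nM in an in vitro assay on 293-EBNA cells for binding affinity to corticotropin-releasing factor receptor 1 (Homo sapiens); a lower number here means a stronger inhibitor, a higher number a weaker inhibitor. Compound 2 `Cc1nc(N2CCCC2)c2nnn(-c3ccc(C(C)C)cc3Br)c2n1` gives 194 nM.

Of these two numbers, compound 2 holds the higher one; compound 1 stands lower by a step that lies beyond the usual scatter. Compound 3 `COCC(COC)N(C)c1nc(C)nc2c1nnn2-c1ccc(C(C)C)cc1Br` keeps the core of compound 2 and alters one group: a group of 9 heavy atoms (6 carbon, 1 nitrogen, 2 oxygen; no ring) in place of a group of 5 heavy atoms (4 carbon, 1 nitrogen; one five-membered non-aromatic ring with 1 hetero atom), on an aromatic carbon. Among the compounds with values here, no measured pair shows this exact change, and compound 1 differs from compound 2 in two places at once, so it offers no clean guide. A modest move toward a lower number is expected for compound 3, estimated at 60 nM with a range of 15 nM to 250 nM. The expected step is a 3.2-fold lower number from compound 2 to compound 3 (0.51 log units; beyond the scatter).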

Compound 3, inhibition constant: 21.3 nM
Beside the measured number, compound 3's estimate is 2.8-fold (0.45 log units) above it; low and high end bracket the measured number.
By their numbers in this assay, from the lowest: compound 3; then compound 1; then compound 2.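

In this assay, a 9.1-fold lower number from compound 2 to compound 3 (0.96 log units; beyond the scatter) comes with replacing pyrrolidin-1-yl by the larger open-chain group on this aromatic carbon. The lower number shows that a ring is not needed at this position, and that a group with more atoms and more hydrogen-bond acceptors is accepted there. No measurement shown here explains the change.

This single step cannot separate losing the ring from gaining the two oxygens. A dipropylamino group, with no oxygen, or a morpholine ring, which keeps a ring and adds one oxygen, would help to tell these apart.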